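Sulfonamide series: the step from compound 2 to compound 4

The compounds below may be only part of what the source reports. "The series", "measured", "known", "first", "only" and "open" are said of these compounds alone.

Measured in a functional assay (plasma) for inhibition, with Oryctolagus cuniculus as the target; on this read-out lower numbers stand for stronger inhibition and higher numbers for weaker inhibition
compound 1 `Cc1ccc(S(=O)(=O)N[C@H]2C3CC[C@H](C3)[C@@H]2C/C=C\CCCC(=O)O)cc1` gives 500 nM
compound 2 `CN(C)c1ccc(S(=O)(=O)N[C@H]2C3CC[C@H](C3)[C@@H]2C/C=C\CCCC(=O)O)cc1` gives 7100 nM
compound 3 `O=C(O)CCC/C=C\C[C@H]1[C@@H]2CCC(C2)[C@@H]1NS(=O)(=O)c1cccc2ccccc12` gives 1100 nM

Compound 2 stands highest of the three in this assay. Compound 4 `O=C(O)CCC/C=C\C[C@H]1[C@@H]2CCC(C2)[C@@H]1NS(=O)(=O)CCCc1ccccc1` changes it at the sulfonyl sulfur, and the difference is 3-phenylpropyl in place of 4-(dimethylamino)phenyl on a sulfonyl sulfur. Two measured steps replace the same group at that place, namely a 14-fold higher number from compound 1 to compound 2 (1.15 log units; beyond the scatter), which is large, and a 6.5-fold lower number from compound 2 to compound 3 (0.81 log units; beyond the scatter), which is modest. Both leave compound 2 with the higher number, while a 2.2-fold higher number from compound 1 to compound 3 (0.34 log units; beyond the scatter) separates the other two. Among the compounds with values here, no measured compound carries 3-phenylpropyl, so a modest fall in this assay is expected, with wide uncertainty. The expected change is a 3.6-fold lower number from compound 2 to compound 4 (0.55 log units; beyond the scatter). Compound 4 is estimated at 2000 nM, within a range of 500 nM to 8000 nM.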

Compound 4, half-maximal inhibitory concentration: 14000 nM
For compound 4 the middle estimate is 7.0-fold (0.85 log units) below the measured one, outside the stated range (above it).
By their numbers in this assay, from the lowest: compound 1; then compound 3; then compounds 2 and 4 (each within the scatter of the next).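

In this assay, compound 4 cannot be told apart from compound 2 (a 2.0-fold higher number from compound 2 to compound 4 (0.29 log units; within the scatter)), although 3-phenylpropyl replaces 4-(dimethylamino)phenyl on the sulfonyl sulfur. 3-Phenylpropyl does not match naphthalen-1-yl (a 13-fold higher number from compound 3 to compound 4 (1.10 log units; beyond the scatter)) or 4-methylphenyl (a 28-fold higher number from compound 1 to compound 4 (1.45 log units; beyond the scatter)), so this position separates these groups widely, with compound 2 showing that an aromatic ring directly on sulfur does not by itself give the lower numbers. Nothing available here accounts for these differences.

Open, going by these compounds, is whether benzyl or 2-phenylethyl on the sulfonyl sulfur would fall nearer compound 1 or compound 4. Also open, on these data alone, is how 4-methoxyphenyl or 4-chlorophenyl would compare with 4-methylphenyl.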